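Sulfoxide and aniline in place of the sulfide acid

The source may hold more compounds than are shown below. What is called first, only, known or untested is meant among the compounds shown, and "the series" means these compounds.

Measured compounds in an assay for binding affinity to leukotriene B4 receptor 1 (Homo sapiens); a lower number here means a stronger inhibitor, a higher number a weaker inhibitor:
- compound 1, `COc1ccc(CCCCCCCCOc2ccc(C[S+]([O-])c3cccc(C(=O)O)c3)nc2/C=C/C(=O)O)cc1`: 151 nM
- compound 2, `COc1ccc(CCCCCCCCOc2ccc(CSc3cccc(C(=O)O)c3)nc2/C=C/C(=O)O)cc1`: 80 nM
- compound 3, `COc1ccc(CCCCCCCCOc2ccc(CSc3cccc(NS(=O)(=O)C(F)(F)F)c3)nc2/C=C/C(=O)O)cc1`: 284 nM

Compound 2 has the lowest number of the three, though compound 1 sits within the scatter of it, while compound 3 lies beyond the scatter, as the step of a 3.6-fold higher number from compound 2 to compound 3 (0.55 log units; beyond the scatter) shows. The step of a 1.9-fold lower number from compound 1 to compound 2 (0.28 log units; within the scatter) shows that the change from compound 1 to compound 2 did not move the number beyond the scatter.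

Compound 4, `COc1ccc(CCCCCCCCOc2ccc(C[S+]([O-])c3cccc(N)c3)nc2/C=C/C(=O)O)cc1`, has not yet been measured. It differs from compound 2 in one place: a group of 9 heavy atoms (6 carbon, 1 nitrogen, 1 oxygen, 1 sulfur; one six-membered aromatic ring of carbon only) in place of a group of 10 heavy atoms (7 carbon, 2 oxygen, 1 sulfur; one six-membered aromatic ring of carbon only), on a saturated chain carbon bound to an aromatic carbon. This change combines two parts. One part resembles the reverse of the change from compound 1 to compound 2, where a 1.9-fold lower number from compound 1 to compound 2 (0.28 log units; within the scatter) was small. The other part removes the carboxy from the aromatic ring, as in the change from compound 2 to compound 3, where a 3.6-fold higher number from compound 2 to compound 3 (0.55 log units; beyond the scatter) was a modest loss. Nothing measured here covers an amino on that ring, so the expectation leans on the loss seen with compound 3.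

The estimate for compound 4 is therefore a somewhat higher number than compound 2, namely a 5.0-fold higher number from compound 2 to compound 4 (0.70 log units; beyond the scatter). Compound 4 is expected to give about 400 nM, with a range from 120 nM to 1500 nM.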

Compound 4, inhibition constant: 4.7 nM
Compound 4: middle estimate off by 85-fold (1.93 log units), on the high side; the whole stated range lies above it.
By their numbers in this assay, from the lowest: compound 4; then compounds 2, 1 and 3 (each within the scatter of the next, the first and the last beyond it).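

In this assay, amino in place of carboxy on an aromatic carbon gives a 32-fold lower number from compound 1 to compound 4 (1.51 log units; beyond the scatter) and so shows that a carboxy on this ring is not needed for a low number at this place. The only earlier replacement of that carboxy, a 3.6-fold higher number from compound 2 to compound 3 (0.55 log units; beyond the scatter) with ((trifluoromethyl)sulfonyl)amino entering, went the other way, so the outcome depends on which group enters, although that step was taken on the sulfide and the new one on the sulfoxide. The step of a 17-fold lower number from compound 2 to compound 4 (1.23 log units; beyond the scatter) changes the sulfur and the ring group together, and the data shown offer no measurement that explains the gain.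

The step of a 1.9-fold lower number from compound 1 to compound 2 (0.28 log units; within the scatter) stays within the scatter for the acids, but that does not show that the sulfur makes no difference once amino is present, and a sulfide carrying a 3-aminophenyl group would separate the two parts of the change. As far as these compounds go, it also remains open whether the gain is specific to amino or is shared by a hydroxy, a methylamino or an acetylamino group in the same place.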